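Heptyl in Place of Hydrogen on a Fused Core

The source may report more compounds than this note shows. Statements on the series, on what has been measured and on what is new or still open speak of the compounds shown alone.

Of the compounds shown here, three have so far been tested in a functional assay on HEL cells (Homo sapiens), read by microscopy; on this read-out lower numbers stand for higher toxicity in this test and higher numbers for lower toxicity in this test. Compound 3 `OCCOCn1cc2ccnc-2nc1O` reached only a limit there, > 400000 nM, so it stands at the limit of > 400000 nM in this assay, at which 1 of the 3 values shown sits, with no number of its own. Compound 1 `CCCCCCCCCc1cc2cn(COCCO)c(O)nc-2n1` also gave only a limit, > 80000 nM, which is the limit of > 80000 nM in this assay, at which 1 of the 3 values shown sits. Compound 2 `CCCCCC#Cc1cc2cn(COCCO)c(=O)nc2o1` likewise stopped at a limit, >= 100000 nM, which is the limit of >= 100000 nM in this assay, at which 1 of the 3 values shown sits. Compound 4 `CCCCCCCc1cc2cn(COCCO)c(O)nc-2n1` has not been tested; it differs from compound 3 by heptyl in place of hydrogen on an aromatic carbon. Within the data shown here, no measured step between compounds that differ in a single place is available. Since every value shown is a limit, the step from compound 3 to compound 4 is expected to be an at least 4.0-fold lower number from compound 3 to compound 4 (0.60 log units; beyond the scatter), small or none beyond the scatter. Compound 4 is estimated at 100000 nM, between 30000 nM and 400000 nM.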

Compound 4, minimum cytotoxic concentration: >= 400000 nM
Compound 4 ended at the assay's limit (the forecaster's own chance of this, stated with the estimate: 80%); middle value at least 4.0-fold (0.60 log units) from the limit.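

Compound 4 stopped at a limit, >= 400000 nM. Among these compounds, compound 1 and compound 3 also stand at limits, so no step from either to compound 4 can be read. As far as these compounds go, whether heptyl in place of hydrogen changes the read-out in this assay stays open.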